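A few compounds are considered here, and "the series" means these few. Any claim that something is new, unique, unknown or untested is made for them only; others in the source may bear on it.

Measured so far:
compound 1 `COc1cccc(OC)c1C(=O)Nc1nnc(-c2ccccc2)s1` — 282 nM
compound 2 `COc1cccc(OC)c1C(=O)Nc1nnc(-c2ccc(Br)cc2)s1` — 45.7 nM
compound 3 `COc1cccc(OC)c1C(=O)Nc1nnc(-c2ccc(C#N)cc2)s1` — 200 nM

All three share one core and differ only in the group on the phenyl ring attached to it. In a functional assay on the whole organism (integument) for inhibition, with Chilo suppressalis as the target, read by scintillation counting, with a stated time of 72 h, in the presence of a further agent that is not named here (a higher number here means a weaker inhibitor, a lower number a stronger inhibitor), compound 2 gives the lowest number of the three: the step of a 6.2-fold lower number from compound 1 to compound 2 (0.79 log units; beyond the scatter) lies beyond the scatter, and so does the step of a 4.4-fold higher number from compound 2 to compound 3 (0.64 log units; beyond the scatter). Compound 3 sits close to compound 1, since a 1.4-fold lower number from compound 1 to compound 3 (0.15 log units; within the scatter) is within the scatter. Compound 2 is therefore the strongest inhibitor among the three in this assay.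

Compound 4 `CCOc1ccc(-c2nnc(NC(=O)c3c(OC)cccc3OC)s2)cc1` is not yet measured. It differs from compound 2 in one place: ethoxy in place of bromo on an aromatic carbon. Going by the values given here, no measured step involves an ethoxy group, so the steps that bear on this change are only those that vary the same position: bromo against hydrogen and bromo against cyano. Both replacements of bromo so far gave higher numbers, by modest amounts. On that basis compound 4 is expected to give a higher number than compound 2, with the step of a 2.4-fold higher number from compound 2 to compound 4 (0.38 log units; beyond the scatter) estimated as modest rather than large. The estimate for compound 4 in this assay is 110 nM, with a range from 35 nM to 350 nM.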

Compound 4, half-maximal inhibitory concentration: 95.5 nM
Compound 4: middle estimate off by 1.2-fold (0.06 log units), on the high side; the range from low to high includes it.
By their numbers in this assay, from the lowest: compound 2; then compound 4; then compounds 3 and 1 (each within the scatter of the next).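

Going by these compounds alone, at this position bromo is no longer the only group that moves the number beyond the scatter relative to the unsubstituted compound in this assay: ethoxy does so too, with a 3.0-fold lower number from compound 1 to compound 4 (0.47 log units; beyond the scatter) while the step from hydrogen to cyano stayed within the scatter. Ethoxy also separates from cyano, with a 2.1-fold lower number from compound 3 to compound 4 (0.32 log units; beyond the scatter) showing that replacing hydrogen at this position does not bring the same result with every group. Bromo still keeps the lowest number, with a 2.1-fold higher number from compound 2 to compound 4 (0.32 log units; beyond the scatter) showing that ethoxy, with three heavy atoms against one and one hydrogen-bond acceptor against none, does not match it here, so compound 2 remains the strongest inhibitor of the four.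

The four compounds keep the rest of the molecule fixed and offer a single example of each group, so they leave open how a smaller methoxy, a longer chain such as butoxy, an amine or a carboxylic acid would behave at this place, and whether the order would hold with the group elsewhere on the ring. Nothing reported alongside these numbers explains the order of the groups.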